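Swapping the indole nitrogen substituent in a propargylamine series

The source may hold more compounds than are shown below. What is called first, only, known or untested is meant among the compounds shown, and "the series" means these compounds.

Of the compounds shown here, three of one family have been measured in an assay on BTI cells for inhibition of Amine oxidase [flavin-containing] B (Homo sapiens), read by fluorescence, with stated times of 30 min and 1 h; on this read-out higher numbers stand for weaker inhibition and lower numbers for stronger inhibition. Compound 1 `C#CCNC1CCc2c(OCCCN3CCN(c4cccc5c4ccn5Cc4cccc(Cl)c4)CC3)cccc21` gives only a limit of the assay, > 1000 nM; this is a limit, not a number (the limit of > 1000 nM in this assay, at which 1 of the 3 values shown sits). Compound 2 `C#CCNC1CCc2c(OCCCCN3CCN(c4cccc5c4ccn5Cc4cccc(Cl)c4)CC3)cccc21` gives 270 nM in this assay. Compound 3 `C#CCNC1CCc2c(OCCCCCN3CCN(c4cccc5c4ccn5Cc4cccc(Cl)c4)CC3)cccc21` gives 460 nM in this assay, and the gap between compound 2 and compound 3 lies within the usual scatter, so neither can be placed above the other. Compound 2 therefore holds the lowest of the two numbers shown, with compound 3 close to it and compound 1 known only as a limit.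

Compound 4 `C#CCNC1CCc2c(OCCCCN3CCN(c4cccc5c4ccn5S(=O)(=O)c4ccccc4)CC3)cccc21` has not yet been measured in this assay. It differs from compound 2 in one place: phenylsulfonyl in place of 3-chlorobenzyl on an aromatic nitrogen. For the measured compounds named here, no measured pair shows this change, so its effect is open. Going by the values given here, a moderate step toward a higher number is expected, a 2.0-fold higher number from compound 2 to compound 4 (0.31 log units; beyond the scatter), since the new group carries two acceptors where none stood before and the series has no precedent for it. Compound 4 is estimated at 550 nM in this assay, with a range from 150 nM to 2000 nM.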

Compound 4, half-maximal inhibitory concentration: > 1000 nM
Compound 4 was reported as a limit; the forecaster's own chance of this, stated with the estimate: 25%; middle value at least 1.8-fold (0.25 log units) away from the limit.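

For the compounds shown here, until now only the chain varied, with 3-chlorobenzyl held constant on the aromatic nitrogen, so this is the first look at what that position tolerates. Phenylsulfonyl in place of 3-chlorobenzyl gives an at least 3.7-fold higher number from compound 2 to compound 4 (0.56 log units; beyond the scatter), which shows that inhibition depends on the group at this nitrogen and not on the chain alone. Compound 4 stands at a limit of the assay, so this step gives only the smallest possible size of the change: the limit of > 1000 nM in this assay, at which 2 of the 4 values shown sit.

The compounds shown leave open whether the sulfonyl link or the missing chlorine accounts for the step; an unsubstituted benzyl or a 3-chlorophenylsulfonyl group on the same nitrogen would separate the two. From the compounds shown here alone, it also remains open how phenylsulfonyl would behave on the chains of compound 1 and compound 3.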